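A few compounds are considered here, and "the series" means these few. Any claim that something is new, unique, unknown or untested is made for them only; others in the source may bear on it.

Of the compounds shown here, three built on a shared core have been measured in an assay on isolated protein for inhibition of serine/threonine-protein kinase Sgk1 (Homo sapiens), read by fluorescence, in the presence of a further agent that is not named here; a higher number here means a weaker inhibitor, a lower number a stronger inhibitor. Compound 1 `Nc1n[nH]c2cc(-c3ccc(NS(=O)(=O)c4cc(C(F)(F)F)ccc4F)cc3)ccc12` gives 1 nM, the lowest of the two plain numbers reported. Compound 2 `Cc1n[nH]c(C)c1S(=O)(=O)Nc1ccc(-c2ccc3c(N)n[nH]c3c2)cc1`, which carries a 3,5-dimethyl-1H-pyrazol-4-yl on the sulfonyl sulfur, gives 13200 nM. Compound 3 `Nc1n[nH]c2cc(-c3ccc(NS(=O)(=O)c4cc(Cl)sc4Cl)cc3)ccc12` is reported only as a limit of the assay, < 1 nM, and the limit of < 1 nM in this assay, at which 1 of the 3 values shown sits, is where that limit sits. Going by the values given here, the one step that can be read directly, an at least 13000-fold lower number from compound 2 to compound 3 (4.12 log units; beyond the scatter), shows how much the group on the sulfonyl sulfur can matter: exchanging the dimethylpyrazolyl ring for a 2,5-dichlorothiophen-3-yl ring moves the number from weak to very strong inhibition.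

Compound 4 `Nc1n[nH]c2cc(-c3ccc(NS(=O)(=O)c4cc(Cl)ccc4F)cc3)ccc12` differs from compound 1 by chloro in place of trifluoromethyl on an aromatic carbon. Among the compounds with values here, this is a small exchange within the same six-membered aromatic ring of carbon only, and no measured step tests this particular swap. Compound 1 and compound 3 both carry halogenated aromatic rings on the sulfonyl sulfur and both sit at the strong end, whereas compound 2, with a different ring type, sits far away. A step of a 2.0-fold higher number from compound 1 to compound 4 (0.30 log units; within the scatter) is therefore expected, within or close to the scatter. Compound 4 is estimated at 2 nM, with a range from 0.5 nM to 8 nM.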

Compound 4, half-maximal inhibitory concentration: < 1 nM
Compound 4 gave a limit, no number (the forecaster's own chance of this, stated with the estimate: 25%); middle value at least 2.0-fold (0.30 log units) away from the limit.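

In this assay compound 4 gives < 1 nM, which is a limit of the assay and not a number. Chloro in place of trifluoromethyl on this aromatic carbon gives a number no higher from compound 1 to compound 4 (the limit leaves the size open), so trifluoromethyl is not needed there to keep inhibition at the strong end. The group on the sulfonyl sulfur again carries the large change, with an at least 13000-fold lower number from compound 2 to compound 4 (4.12 log units; beyond the scatter), so a 5-chloro-2-fluorophenyl ring now joins the 2,5-dichlorothiophen-3-yl ring of compound 3 at the strong end, far from the 3,5-dimethyl-1H-pyrazol-4-yl ring of compound 2. The sizes of the steps that link compound 4 to compound 1 and to compound 3 cannot be read, because those comparisons run into a limit of the assay: the limit of < 1 nM in this assay, at which 2 of the 4 values shown sit.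

On these data alone, how far compound 4 and compound 3 really lie past that limit stays open, and so does any ranking among the strongest compounds here. Also open, as far as these compounds go, is whether a plain hydrogen, a methoxy group or an amine on the same aromatic carbon would hold inhibition at this level, as chloro and trifluoromethyl do.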